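Methyl for Chloro at the Far Ring of a Chalcone Series

A few compounds are considered here, and "the series" means these few. Any claim that something is new, unique, unknown or untested is made for them only; others in the source may bear on it.

Measured so far:
compound 1 `COc1ccc(-c2cc(C(=O)/C=C/c3ccccc3)nc3cc(-c4ccccc4)nn23)cc1OC` gives 18600 nM in a functional assay on A549 cells (Homo sapiens) for antiproliferative activity, read by MTT assay, with a stated time of 24 h; a lower number here means a stronger inhibitor, a higher number a weaker inhibitor
compound 2 `COc1ccc(/C=C/C(=O)c2cc(-c3ccc(OC)c(OC)c3)n3nc(-c4ccccc4)cc3n2)cc1` gives 19300 nM in this assay
compound 3 `COc1ccc(-c2cc(C(=O)/C=C/c3ccc(Cl)cc3)nc3cc(-c4ccccc4)nn23)cc1OC` gives 22000 nM in this assay

The three compounds share one core and differ only at the far aromatic ring of the enone arm. Compound 3 carries chloro there, and its number in this assay sits alongside those of compound 1 and compound 2, within the scatter of both: a 1.2-fold higher number from compound 1 to compound 3 (0.07 log units; within the scatter) and a 1.1-fold higher number from compound 2 to compound 3 (0.06 log units; within the scatter). The step of a 1.0-fold higher number from compound 1 to compound 2 (0.02 log units; within the scatter) is likewise within the scatter.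

Compound 4 `COc1ccc(-c2cc(C(=O)/C=C/c3ccc(C)cc3)nc3cc(-c4ccccc4)nn23)cc1OC` continues the same theme: methyl in place of chloro on an aromatic carbon. Every exchange at this position recorded so far, hydrogen to methoxy, hydrogen to chloro and methoxy to chloro, left the number in this assay essentially unchanged, so no step beyond the scatter is expected here either. The expected step is a 1.1-fold lower number from compound 3 to compound 4 (0.04 log units; within the scatter). Compound 4 is therefore estimated at 20000 nM in this assay, with a range from 10000 nM to 40000 nM.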

Compound 4, half-maximal inhibitory concentration: 22200 nM
Beside the measured number, compound 4's estimate is 1.1-fold (0.05 log units) below it, within the range that was stated.
By their numbers in this assay, from the lowest: compounds 1, 2, 3 and 4 (each within the scatter of the next).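

In this assay methyl lines up with chloro (a 1.0-fold higher number from compound 3 to compound 4 (0.00 log units; within the scatter)), with methoxy (a 1.2-fold higher number from compound 2 to compound 4 (0.06 log units; within the scatter)) and with hydrogen (a 1.2-fold higher number from compound 1 to compound 4 (0.08 log units; within the scatter)), so a carbon-attached group now joins the others at the far ring without any step beyond the scatter. All four compounds therefore stand within the scatter of one another, and on this shared core the four groups at this position cannot be told apart by this read-out. No evidence is available to account for this flat result.

Still open, on these data alone, is whether a group of another kind at this position, such as an amine, a carboxylic acid or a longer chain, would give a step beyond the scatter. The compounds shown also differ only at this ring, so they leave open how changes elsewhere on the shared core would read.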